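Acid analogues with a benzyl amine: the next step

This account rests on a few compounds, and the source may have more. Where it says the series, first, only, none or still open, it means among the compounds named here.

Measured so far:
compound 1 `CCOC(=O)c1cnc(NC2CC2)n2nc(-c3ccco3)nc12`: 60.7 nM in an assay on CHO cells for displacement of a labelled ligand from adenosine receptor A1 (Homo sapiens); a lower number here means a stronger inhibitor, a higher number a weaker inhibitor
compound 2 `CNc1ncc(C(=O)O)c2nc(-c3ccco3)nn12`: > 100000 nM in this assay

Compound 2 stands at the limit of this assay: its value > 100000 nM is a limit, not a number (the limit of > 100000 nM in this assay, at which 1 of the 2 values shown sits). Compound 1 differs from compound 2 at more than one place, so its value does not isolate any single change. Compound 3 `O=C(O)c1cnc(NCc2ccc(Cl)cc2)n2nc(-c3ccco3)nc12` differs from compound 2 by 4-chlorophenyl in place of hydrogen on a saturated chain carbon bound to a nitrogen on an aromatic ring. Going by the values given here, with no measured pair covering this change, the step from compound 2 to compound 3 is expected to be an at least 5.0-fold lower number from compound 2 to compound 3 (0.69 log units; beyond the scatter), toward stronger binding but starting from a limit. Compound 3 is estimated at 20000 nM, range 2000 nM to 100000 nM.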

Compound 3, inhibition constant: > 100000 nM
Compound 3: no number, only a limit; the forecaster's own chance of this, stated with the estimate: 40%; at least 5.0-fold (0.69 log units) between middle value and limit.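

Compound 2 and compound 3 both sit at a limit, so no step can be read between them: the limit of > 100000 nM in this assay, at which 2 of the 3 values shown sit.

The compounds shown leave open whether any acid analogue gives a readable number in this assay, and what 4-chlorophenyl in place of hydrogen does where one can be read.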